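Swapping a Sulfonyl for a Carbonyl on the Ring Nitrogen

The source may report more compounds than this note shows. Statements on the series, on what has been measured and on what is new or still open speak of the compounds shown alone.

compound 1 `Cc1cc(C#N)cc(C)c1Oc1nc(Nc2ccc(C#N)cc2)ncc1/C=C/C(=O)NCCOCCO`: > 200 nM
compound 2 `Cc1cc(C#N)cc(C)c1Oc1nc(Nc2ccc(C#N)cc2)ncc1/C=C/C(=O)NC1CCN(S(=O)(=O)C(F)(F)F)CC1`: > 160 nM

In an ADME assay on TZM cells (Homo sapiens) for cytotoxicity, with a stated time of 1 days (a lower number here means that less compound is tolerated, a higher number that more compound is tolerated), compound 1 gives only a limit, > 200 nM. In this assay compound 2 likewise gives only a limit, > 160 nM, so it sits at the limit of > 160 nM in this assay, at which 1 of the 2 values shown sits, with no exact number. Compound 3 `Cc1cc(C#N)cc(C)c1Oc1nc(Nc2ccc(C#N)cc2)ncc1/C=C/C(=O)NC1CCN(C(=O)C(F)(F)F)CC1` differs from compound 2 in one place: (trifluoromethyl)carbonyl in place of (trifluoromethyl)sulfonyl on an amine nitrogen in a ring. Within the data shown here, with both known values being limits, no step can be sized, and the change is not expected to move the result beyond the usual scatter. Compound 3 is therefore expected to give about 300 nM, between 100 nM and 1000 nM, most likely again reported only as a limit. The expected step is a step that the limit leaves unreadable from compound 2 to compound 3.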

Compound 3, half-maximal cytotoxic concentration: > 170 nM
Compound 3: only a limit was reported (the forecaster's own chance of this, stated with the estimate: 80%); the middle value lies beyond the limit too.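

Among these compounds, compound 1, compound 2 and compound 3 all give only limits, so no step among them can be read. Still open, going by these compounds, is whether (trifluoromethyl)carbonyl in place of (trifluoromethyl)sulfonyl changes the exact result in this assay at all.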